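From benzyl to 4-methylphenyl on the aromatic nitrogen

The source may hold more compounds than are shown below. What is called first, only, known or untested is meant among the compounds shown, and "the series" means these compounds.

Measured in a functional assay on T47D cells (Homo sapiens) for antiproliferative activity, read by MTT assay, with a stated time of 72 h; on this read-out higher numbers stand for weaker inhibition and lower numbers for stronger inhibition:
- compound 1 `COc1cc(-c2nccn2CC(C)C)cc(OC)c1OC`: > 100000 nM (a limit)
- compound 2 `CCCCCn1ccnc1-c1cc(OC)c(OC)c(OC)c1`: 64400 nM
- compound 3 `COc1cc(-c2nccn2Cc2ccccc2)cc(OC)c1OC`: > 100000 nM (a limit)

Compound 3 stands at > 100000 nM, which is only a limit and not a number.

Compound 4 `COc1cc(-c2nccn2-c2ccc(C)cc2)cc(OC)c1OC` carries one change: 4-methylphenyl in place of benzyl on an aromatic nitrogen. The closest evidence is an at least 1.5-fold higher number from compound 2 to compound 3 (0.19 log units; that floor lies within the scatter) and an at least 1.5-fold lower number from compound 1 to compound 2 (0.19 log units; that floor lies within the scatter), together with a step that the two limits leave unreadable from compound 1 to compound 3. All three steps keep a saturated chain carbon bound to an aromatic nitrogen, which compound 4 lacks, so they fix no firm size. A lower number in this assay is expected, though the direction is uncertain and a further limit remains possible. The expected result is an at least 3.3-fold lower number from compound 3 to compound 4 (0.52 log units; beyond the scatter). The estimate for compound 4 is 30000 nM, within an estimated range of 2000 nM to 100000 nM.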

Compound 4, half-maximal inhibitory concentration: 20500 nM
Estimate against measurement, compound 4: 1.5-fold (0.17 log units) above, within the range that was stated.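

Moving the ring directly onto the aromatic nitrogen gives the only steps here that are readable beyond the scatter in this assay: an at least 4.8-fold lower number from compound 3 to compound 4 (0.68 log units; beyond the scatter), an at least 4.8-fold lower number from compound 1 to compound 4 (0.68 log units; beyond the scatter) and a 3.1-fold lower number from compound 2 to compound 4 (0.50 log units; beyond the scatter). Compound 4 is thus the most potent of the four, although benzyl and 4-methylphenyl hold the same atoms. Compound 1 and compound 3 each stand at a limit, not a number, so their steps are floors only: the limit of > 100000 nM in this assay, at which 2 of the 4 values shown sit.

On these data alone, whether the gain needs the methyl stays open. Plain phenyl, 4-methoxyphenyl or 4-aminophenyl on the same nitrogen would test this.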